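Swapping Nitro for Chloro on an Aromatic Carbon

The source may hold more compounds than are shown below. What is called first, only, known or untested is meant among the compounds shown, and "the series" means these compounds.

In a functional assay on COLO 205 cells (Homo sapiens) for inhibition, read by sulforhodamine B assay, tested at 10 uM (on this read-out higher numbers stand for more inhibition of growth at the one concentration tested and lower numbers for less inhibition of growth), compound 1 `COc1cc(C2CC(c3ccc([N+](=O)[O-])cc3)=NN2C(C)=O)ccc1OCc1cn(Cc2ccc([N+](=O)[O-])cc2)nn1` gives 33%, which places it at the top of the two numbers recorded, though only nominally: compound 2 `COc1cc(C2CC(c3ccc(Br)cc3)=NN2C(C)=O)ccc1OCc1cn(Cc2ccc([N+](=O)[O-])cc2)nn1`, which carries bromo in place of nitro on an aromatic carbon, gives 26% in this assay, and the step of a number 7 percentage points lower from compound 1 to compound 2 (within the scatter) stays within the scatter, so the two compounds cannot be told apart on these data.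

Compound 3 `COc1cc(C2CC(c3ccc(Cl)cc3)=NN2C(C)=O)ccc1OCc1cn(Cc2ccc([N+](=O)[O-])cc2)nn1` has not been measured. It differs from compound 1 by chloro in place of nitro on an aromatic carbon. Within the data shown here, only one measured step bears on this change, namely a number 7 percentage points lower from compound 1 to compound 2 (within the scatter), in which a different halogen replaced the same nitro group at the same place and produced no movement beyond the scatter. With chloro now taking that place, the account therefore expects no step beyond the scatter in this assay either; the expected change a number 5 percentage points lower from compound 1 to compound 3 (within the scatter) is small. Compound 3 is estimated to give 28% in this assay, with a range from 15% to 42%, before its measurement is known.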

Compound 3, percent growth inhibition at one concentration: 0%
Compound 3: the middle estimate sits 28 percentage points above what was measured, outside the stated range (below it).
By their numbers in this assay, from the lowest: compound 3; then compounds 2 and 1 (each within the scatter of the next).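

In this assay the exchange of 4-nitrophenyl for 4-chlorophenyl is not silent, since the change is a number 33 percentage points lower from compound 1 to compound 3 (beyond the scatter) and lies beyond the scatter, so this aromatic carbon, para to a large group, does respond to what sits on it, which the earlier pair could not show. The two halogens also part company here: the step of a number 26 percentage points lower from compound 2 to compound 3 (beyond the scatter) separates chloro from bromo, although bromo itself remains within the scatter of nitro in the step of a number 7 percentage points lower from compound 1 to compound 2 (within the scatter), so on these data neither halogen can stand in for the other at this place. Nothing measured on these compounds accounts for the loss seen with chloro, and the reason remains unknown.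

The three compounds leave open how fluoro, iodo, a methoxy group or an amine on the same aromatic carbon would read, and so whether chloro is an isolated low point or part of a wider trend. They also leave open whether the gap between chloro and bromo would hold at other concentrations or in other cell lines.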